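From phenyl to 4-chlorophenyl in compound 2

The source may report more compounds than this note shows. Statements on the series, on what has been measured and on what is new or still open speak of the compounds shown alone.

Going by the values given here, in a functional assay on the whole organism for inhibition, with Mus musculus as the target (a higher number here means that more compound is needed for the effect, a lower number that less compound is needed), only two compounds have values so far. Compound 1 (`CN1Cc2c(N)cccc2C(c2ccc(Cl)cc2)C1`) gives 1.6 mg/kg and compound 2 (`CCCCNC(=O)Nc1cccc2c1CN(C)CC2c1ccccc1`) gives about 40 mg/kg, the higher of the two numbers and beyond the scatter from compound 1. Compound 3 (`CCCCNC(=O)Nc1cccc2c1CN(C)CC2c1ccc(Cl)cc1`) places chloro in place of hydrogen on an aromatic carbon of compound 2, turning phenyl into 4-chlorophenyl: chloro in place of hydrogen on an aromatic carbon. Among the compounds with values here, no measured pair shows this change on its own, so the size of the step is a judgement. Compound 1 also bears the 4-chlorophenyl group, and at 1.6 mg/kg it gives only a weak hint towards a lower number. A moderate fall in this assay is expected, though a result within the scatter remains possible. The expected change is a 2.9-fold lower number from compound 2 to compound 3 (0.46 log units; beyond the scatter). The estimate for compound 3 is 14 mg/kg, with an expected range of 4 mg/kg to 45 mg/kg.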

Compound 3, dose for half-maximal effect: 44 mg/kg
Compound 3: middle estimate off by 3.1-fold (0.50 log units), on the low side, and the stated range covers the measured number.
By their numbers in this assay, from the lowest: compound 1; then compounds 2 and 3 (each within the scatter of the next).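

In this assay, chloro in place of hydrogen on the aromatic carbon of compound 2 gives a 1.1-fold higher number from compound 2 to compound 3 (0.04 log units; within the scatter) and leaves the change from phenyl to 4-chlorophenyl indistinguishable from the scatter when butylcarbamoyl is present on the nitrogen. With 4-chlorophenyl held constant, butylcarbamoyl in place of hydrogen on the nitrogen on the aromatic ring gives a 28-fold higher number from compound 1 to compound 3 (1.44 log units; beyond the scatter) and marks that nitrogen, rather than the chloro position, as the place of the large step. Nothing measured here offers an explanation for either step.

Whether chloro matters when that nitrogen carries a free amine remains open, as the phenyl counterpart of compound 1 is not among the compounds shown. Also open, from the compounds shown here alone, are the outcomes with a shorter chain or an acetyl group on the nitrogen, and with fluoro or methoxy in place of chloro.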